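Exchanging a Chain-End Imidazole for a Methylpiperazine

A few compounds are considered here, and "the series" means these few. Any claim that something is new, unique, unknown or untested is made for them only; others in the source may bear on it.

compound 1, `Cn1cc(C2=C(c3nn(CCn4ccnc4)c4ncccc34)C(=O)NC2=O)c2ccccc21`, > 100000 nM
compound 2, `Cn1cc(C2=C(c3nn(CCCN4CCCCC4)c4ncccc34)C(=O)N(c3ccccn3)C2=O)c2ccccc21`, > 100000 nM

Compound 1 carries the structure `Cn1cc(C2=C(c3nn(CCn4ccnc4)c4ncccc34)C(=O)NC2=O)c2ccccc21`. In a functional assay on A549 cells (Homo sapiens) for antiproliferative activity, read by MTT assay, with a stated time of 48 h (a higher number here means a weaker inhibitor, a lower number a stronger inhibitor), compound 1 reaches only the limit of the assay, > 100000 nM, and so stands on no number. Compound 2, `Cn1cc(C2=C(c3nn(CCCN4CCCCC4)c4ncccc34)C(=O)N(c3ccccn3)C2=O)c2ccccc21`, is the other compound measured. In this assay compound 2 likewise gives only a limit, > 100000 nM. Within the data shown here, every value shown so far is the limit of > 100000 nM in this assay, at which 2 of the 2 values shown sit, so no step between measured compounds can be read. Compound 3, `CN1CCN(CCCn2nc(C3=C(c4cn(C)c5ccccc45)C(=O)NC3=O)c3cccnc32)CC1`, differs from compound 1 by (4-methylpiperazin-1-yl)methyl in place of 1H-imidazol-1-yl on a saturated chain carbon, two bonds along the chain from an aromatic nitrogen. Among the measured compounds shown here, with no measured step to build on, the expectation rests on that limit alone. The step of a number no higher from compound 1 to compound 3 (the limit leaves the size open) is expected to stay small, not beyond the scatter, in either direction. Compound 3 is therefore estimated at 100000 nM, within 20000 nM to 500000 nM, and most likely reported again as a limit.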

Compound 3, half-maximal inhibitory concentration: > 100000 nM
Compound 3: a limit, no number; the forecaster's own chance of this, stated with the estimate: 70%; the middle value lies on the limit itself.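

Among these compounds, compound 3 gives only a limit, so no step from compound 1 to compound 3 can be read, and the exchange of groups has no size: the limit of > 100000 nM in this assay, at which 3 of the 3 values shown sit. The compounds shown leave open whether any change on the shared core would give a measurable value.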